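This account rests on a few compounds, and the source may have more. Where it says the series, first, only, none or still open, it means among the compounds named here.

Compound 2 `Cn1nc(-c2ccc(OC[C@H]3CC[C@H](N)CC3)c(F)c2)c2cnc(N)nc21` gives 5 nM in an assay on THP-1 cells for antagonist activity at Toll-like receptor 8 (Homo sapiens); a lower number here means a stronger inhibitor, a higher number a weaker inhibitor; that is the higher of the two numbers at hand, the other belonging to compound 1 `Cc1cc(-c2cnc(OCC34CCC(N)(CC3)CC4)c(C)c2)c2cnn(C)c2n1`, which in this assay gives 2 nM, a number that lies beyond the scatter from that of compound 2. Compound 3 `Cn1nc(-c2ccc(OCC34CCC(O)(CC3)CC4)c(F)c2)c2cnc(N)nc21` has not yet been measured. It differs from compound 2 by a group of 9 heavy atoms (8 carbon, 1 oxygen; 2 six-membered non-aromatic rings of carbon only) in place of a group of 7 heavy atoms (6 carbon, 1 nitrogen; one six-membered non-aromatic ring of carbon only), on a saturated chain carbon bound to an oxygen on an aromatic ring. Among the compounds with values here, no pair of measured compounds covers this change: the amine of compound 2 gives way to an alcohol on a larger bicyclic frame, and the measured compounds offer no step of the same kind to lean on. The step from compound 2 to compound 3 is expected to run toward a higher number, a 6.0-fold higher number from compound 2 to compound 3 (0.78 log units; beyond the scatter), by more than the scatter. Compound 3 is therefore estimated at 30 nM in this assay, within a range from 5 nM to 200 nM.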

Compound 3, half-maximal inhibitory concentration: 75 nM
Compound 3: middle estimate off by 2.5-fold (0.40 log units), on the low side; low and high end bracket the measured number.
By their numbers in this assay, from the lowest: compound 1; then compound 2; then compound 3.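

In this assay the place on a saturated chain carbon bound to an oxygen on an aromatic ring proves sensitive: exchanging 4-aminocyclohexyl for the larger group with 2 six-membered rings and an oxygen brings a 15-fold higher number from compound 2 to compound 3 (1.18 log units; beyond the scatter) and this is a large step. The two groups have the same counts of hydrogen-bond donors and acceptors and no net charge, so those counts alone do not keep the number in place. Nothing at hand accounts for the size of this step.

The exchange alters the ring frame and the nitrogen-to-oxygen swap at once, so the compounds shown cannot assign the loss to either one. Open, on the core of compound 3, is how an amine on the same two-ring frame, or a methyl ether in place of the alcohol, would read.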